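This account rests on a few compounds, and the source may have more. Where it says the series, first, only, none or still open, it means among the compounds named here.

The measured compounds:
compound 1, `Fc1cccc(-c2nc(Nc3ccccc3)c3cc(F)ccc3n2)c1`: in a functional assay on U2OS cells (Homo sapiens) for cytotoxicity, read by MTT assay, with a stated time of 48 h (a lower number here means a stronger inhibitor, a higher number a weaker inhibitor), compound 1 gives 47600 nM.
compound 2, `COc1ccc(Nc2nc(-c3cccc(F)c3)nc3ccc(F)cc23)cc1`: in this assay compound 2 gives 32300 nM.
compound 3, `Fc1cccc(-c2nc(Nc3ccc(Cl)cc3)c3cc(F)ccc3n2)c1`: in this assay compound 3 gives 38400 nM.

Compound 2 holds the lowest of the three numbers, yet its gaps to the other two lie within the scatter of repeated measurements: a 1.5-fold lower number from compound 1 to compound 2 (0.17 log units; within the scatter), and a 1.2-fold higher number from compound 2 to compound 3 (0.08 log units; within the scatter). Nothing here separates the three compounds.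

Compound 4, `Fc1cccc(-c2nc(Nc3cccc(Cl)c3)c3cc(F)ccc3n2)c1`, has not yet been measured in this assay. It differs from compound 2 in one place: 3-chlorophenyl in place of 4-methoxyphenyl on a nitrogen on an aromatic ring. Among the compounds with values here, three measured steps bear on this change. Methoxy in place of hydrogen gave a 1.5-fold lower number from compound 1 to compound 2 (0.17 log units; within the scatter); chloro in place of hydrogen gave a 1.2-fold lower number from compound 1 to compound 3 (0.09 log units; within the scatter); and the direct exchange of methoxy for chloro gave a 1.2-fold higher number from compound 2 to compound 3 (0.08 log units; within the scatter). Every one of them stayed within the scatter, so a chloro on the phenyl attached to the ring nitrogen is not expected to move the number beyond the scatter in either direction. Compound 4 is therefore expected to give about 40000 nM, in the range 20000 nM to 80000 nM. Within the data shown here, the estimate amounts to an expected step of a 1.2-fold higher number from compound 2 to compound 4 (0.09 log units; within the scatter), which is no real step at all.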

Compound 4, half-maximal inhibitory concentration: > 50000 nM
Compound 4: no number, only a limit; the forecaster's own chance of this, stated with the estimate: 15%; at least 1.2-fold (0.09 log units) between middle value and limit.
By their numbers in this assay, from the lowest: compounds 2, 3 and 1 (each within the scatter of the next). At a limit, above all of these: compound 4.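

Compound 4 stands at a limit of this assay, not at a number: the limit of > 50000 nM in this assay, at which 1 of the 4 values shown sits.

Read from that limit, 3-chlorophenyl in place of 4-methoxyphenyl gives an at least 1.5-fold higher number from compound 2 to compound 4 (0.18 log units; that floor lies within the scatter), 3-chlorophenyl in place of 4-chlorophenyl gives an at least 1.3-fold higher number from compound 3 to compound 4 (0.11 log units; that floor lies within the scatter), and chloro in place of hydrogen gives an at least 1.0-fold higher number from compound 1 to compound 4 (0.02 log units; that floor lies within the scatter). What the earlier compounds did not show is that a change in this place, on a nitrogen on an aromatic ring, can leave the assay without a number: 3-chlorophenyl gives only a limit, where 4-chlorophenyl and 4-methoxyphenyl gave numbers, yet no floor is shown beyond the scatter, so the true size of these steps remains unknown.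

On these data alone, whether the value of compound 4 lies just past the limit or far from it stays open, and with it whether the difference between 3-chlorophenyl and 4-chlorophenyl is real. How an amine or a carboxylic acid on that phenyl would read in this assay is also left open by the compounds shown.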